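Fluoro for chloro, from compound 1 to compound 4

This account rests on a few compounds, and the source may have more. Where it says the series, first, only, none or still open, it means among the compounds named here.

Measured compounds:
compound 1 `COc1ccc(/C=C2\CN(C(=S)SCc3cn(Cc4ccccc4Cl)nn3)C/C(=C\c3ccc(OC)cc3)C2=O)cc1`: > 100000 nM
compound 2 `O=C1/C(=C/c2ccccc2F)CN(C(=S)SCc2cn(Cc3cccc(Cl)c3)nn2)C/C1=C\c1ccccc1F`: > 100000 nM
compound 3 `O=C1/C(=C/c2ccccc2F)CN(Cc2cn(Cc3ccccc3Cl)nn2)C/C1=C\c1ccccc1F`: 5300 nM

In a functional assay on 4T1 cells (Mus musculus) for cytotoxicity, read by MTT assay, with a stated time of 24 h (on this read-out higher numbers stand for weaker inhibition and lower numbers for stronger inhibition), compound 1 reaches only an assay limit, > 100000 nM, so no number is known for it. Compound 2 likewise stops at a limit, > 100000 nM. Compound 3 gives a measured value, 5300 nM. The series thus stands largely at the limit of > 100000 nM in this assay, at which 2 of the 3 values shown sit.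

Compound 4 `COc1ccc(/C=C2\CN(C(=S)SCc3cn(Cc4ccccc4F)nn3)C/C(=C\c3ccc(OC)cc3)C2=O)cc1` differs from compound 1 by fluoro in place of chloro on an aromatic carbon; all else in the shared core is unchanged. For so small an exchange, and with compound 1 itself at a limit, the step from compound 1 to compound 4 in this assay is expected to be a step that the limit leaves unreadable from compound 1 to compound 4, nothing beyond the usual scatter. Compound 4 is therefore estimated at 150000 nM, with a range from 30000 nM to 600000 nM, most probably again reported only as a limit.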

Compound 4, half-maximal inhibitory concentration: 49900 nM
Compound 4: the middle estimate sits 3.0-fold (0.48 log units) above what was measured; low and high end bracket the measured number.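

In this assay the exchange of 2-chlorobenzyl for 2-fluorobenzyl gives an at least 2.0-fold lower number from compound 1 to compound 4 (0.30 log units; that floor lies within the scatter) and so brings the shared core of compound 1 to a measured number rather than a limit. That step is only a floor and the floor stays within the scatter, so no firm gain from fluoro at this place can be claimed. The reading rests on a series still mostly at its limit: the limit of > 100000 nM in this assay, at which 2 of the 4 values shown sit.

Going by these compounds, the true size of the step remains open. So does whether a bromo, methyl or methoxy group on the same aromatic carbon would also give a measured number.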